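Swapping the Chain-End Amine in a Cytotoxic Series

The compounds below may be only part of what the source reports. "The series", "measured", "known", "first", "only" and "open" are said of these compounds alone.

Compound 1 `O=C1c2c[n+]([O-])c3ccccc3c2C(=O)c2c1c1ccccc1n2CCCCn1ccnc1` is tested in a functional assay on A-375 cells (Homo sapiens) for cytotoxicity, read by MTT assay, with a stated time of 72 h (on this read-out lower numbers stand for stronger inhibition and higher numbers for weaker inhibition), where compound 1 gives 350 nM. Among the three measured compounds it holds the second highest number. Compound 2 `O=C1c2c[n+]([O-])c3ccccc3c2C(=O)c2c1c1ccccc1n2CCN1CCCCC1` gives 180 nM and compound 3 `CN1CCN(CCCCCCn2c3c(c4ccccc42)C(=O)c2c[n+]([O-])c4ccccc4c2C3=O)CC1` gives 630 nM. The change from compound 1 to compound 4 `CN(C)CCCCn1c2c(c3ccccc31)C(=O)c1c[n+]([O-])c3ccccc3c1C2=O` is dimethylamino in place of 1H-imidazol-1-yl on a saturated chain carbon, four bonds along the chain from an aromatic nitrogen. Three measured steps also alter the group carried at the end of the chain: a 1.9-fold lower number from compound 1 to compound 2 (0.29 log units; within the scatter), a 1.8-fold higher number from compound 1 to compound 3 (0.26 log units; within the scatter) and a 3.5-fold higher number from compound 2 to compound 3 (0.54 log units; beyond the scatter). Since two of these steps sit within the scatter and the third is only modest, the step in this assay is expected to be small or none beyond the scatter. Compound 4 is therefore estimated at 300 nM, with a range from 120 nM to 800 nM. The expected step reads a 1.2-fold lower number from compound 1 to compound 4 (0.07 log units; within the scatter).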

Compound 4, half-maximal inhibitory concentration: 470 nM
The estimate for compound 4 lay 1.6-fold (0.19 log units) below the measured number, and the stated range covers the measured number.
By their numbers in this assay, from the lowest: compounds 2, 1, 4 and 3 (each within the scatter of the next, the first and the last beyond it).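

In this assay the ring of 1H-imidazol-1-yl gives way to the ringless dimethylamino with a 1.3-fold higher number from compound 1 to compound 4 (0.13 log units; within the scatter) as the whole result, so at this chain end the aromatic ring is not required to hold this level of activity. The other new steps read a 1.3-fold lower number from compound 3 to compound 4 (0.13 log units; within the scatter) and a 2.6-fold higher number from compound 2 to compound 4 (0.42 log units; beyond the scatter) and only the second of these lies beyond the scatter. No measured evidence gives a reason for these steps. On these data alone, it remains open how a primary amine, a morpholine or a carboxylic acid would behave at the chain end, and whether dimethylamino would keep its level on a shorter or longer chain.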